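Propyl amide in place of hydroxycyclohexyl amide

The compounds below may be only part of what the source reports. "The series", "measured", "known", "first", "only" and "open" are said of these compounds alone.

Measured compounds:
compound 1 `CNC(=O)c1cc(C(=O)N[C@H]2CC[C@H](O)CC2)n([C@@H](C)c2ccccc2)n1`: 80 nm/s
compound 2 `CC[C@@H](c1ccccc1)n1nc(C(=O)NC)cc1C(=O)N[C@H]1CC[C@H](O)CC1`: 70 nm/s

In an ADME assay for permeability (a higher number here means that the compound crosses the layer faster, a lower number that the compound crosses the layer more slowly), compound 1 gives 80 nm/s, the higher of the two numbers but within the scatter of compound 2. Within the data shown here, the one measured step, a 1.1-fold lower number from compound 1 to compound 2 (0.06 log units; within the scatter), concerns a methyl on the saturated chain carbon and says nothing about the amide substituent. Compound 3 `CCCNC(=O)c1cc(C(=O)NC)nn1[C@@H](C)c1ccccc1` differs from compound 1 as propyl in place of 4-hydroxycyclohexyl on an amide-type nitrogen. Among the measured compounds shown here, no measured step bears on this change; the group leaving carries one hydrogen-bond donor and one acceptor, the propyl none. The expectation is a larger number, a 3.1-fold higher number from compound 1 to compound 3 (0.49 log units; beyond the scatter). Compound 3 is therefore estimated at 250 nm/s, between 120 nm/s and 500 nm/s.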

Compound 3, apparent permeability: 560 nm/s
For compound 3 the middle estimate is 2.2-fold (0.35 log units) below the measured one, and the stated range ends below it.
By their numbers in this assay, from the lowest: compounds 2 and 1 (each within the scatter of the next); then compound 3.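

At the amide-type nitrogen, this assay responds strongly to the change of group, with a 7.0-fold higher number from compound 1 to compound 3 (0.85 log units; beyond the scatter) as propyl replaces 4-hydroxycyclohexyl. This single step removes the six-membered ring, the hydrogen-bond donor, the hydrogen-bond acceptor and both defined stereocentres together, and it does not separate their contributions. No measurement at hand gives a cause for the step.

As far as these compounds go, still open in this assay is whether an unsubstituted cyclohexyl on this nitrogen would read closer to compound 1 or compound 3. From the compounds shown here alone, the effects of a longer chain such as pentyl, or of a terminal amine on the propyl chain, also remain open.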